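Swapping Bromo for Trifluoromethyl on the Benzyl Ether

The compounds below may be only part of what the source reports. "The series", "measured", "known", "first", "only" and "open" are said of these compounds alone.

Measured compounds:
compound 1 `Cc1c(C2CC2)nc2ccc(-n3ccc(OCc4ccccc4)cc3=O)cn12`: 28 nM
compound 2 `Cc1c(C2CC2)nc2ccc(-n3ccc(OCc4ccc(Br)cc4)cc3=O)cn12`: 9.3 nM

In an assay on CHO cells for displacement of a labelled ligand from melanin-concentrating hormone receptor 1 (Rattus norvegicus), read by scintillation counting, with a stated time of 1 h (on this read-out higher numbers stand for weaker inhibition and lower numbers for stronger inhibition), compound 2 stands at the lower of the two numbers, with compound 1 set apart by the step of a 3.0-fold lower number from compound 1 to compound 2 (0.48 log units; beyond the scatter). Compound 3 `Cc1c(C2CC2)nc2ccc(-n3ccc(OCc4ccc(C(F)(F)F)cc4)cc3=O)cn12` differs from compound 2 by trifluoromethyl in place of bromo on an aromatic carbon. Among the compounds with values here, only one step has been measured, and it concerns bringing bromo in rather than exchanging it for another group, so no measured step bears directly on this exchange. For compound 3 the expected step is therefore small, a 1.3-fold higher number from compound 2 to compound 3 (0.11 log units; within the scatter), not beyond the scatter. Compound 3 is expected to give 12 nM, within 5 nM to 30 nM.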

Compound 3, half-maximal inhibitory concentration: 82 nM
The estimate for compound 3 lay 6.8-fold (0.83 log units) below the measured number, outside the stated range (above it).
By their numbers in this assay, from the lowest: compound 2; then compound 1; then compound 3.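

In this assay, the group at this place on the aromatic ring matters a great deal: trifluoromethyl in place of bromo gives an 8.8-fold higher number from compound 2 to compound 3 (0.95 log units; beyond the scatter) and shows that the two groups are not interchangeable here. Adding a group does not help as such, since trifluoromethyl in place of hydrogen gives a 2.9-fold higher number from compound 1 to compound 3 (0.47 log units; beyond the scatter) and so runs opposite to the gain seen with bromo. Nothing measured here explains the difference between bromo and trifluoromethyl.

Open, going by these compounds, is how chloro, methoxy or an amine at this place would compare with bromo.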